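Carbonate to amino ester: cytotoxicity notes on the series

The source may hold more compounds than are shown below. What is called first, only, known or untested is meant among the compounds shown, and "the series" means these compounds.

In a functional assay on MT4 cells (Homo sapiens) for cytotoxicity (a higher number here means that more compound is tolerated, a lower number that less compound is tolerated), compound 1 `CCCCOC(=O)OCC1OC(n2cc(C)c(=O)[nH]c2=O)CC1N=[N+]=[N-]` gives > 50000 nM, which is a limit of the assay.
In this assay compound 2 `Cc1cn(C2CC(N=[N+]=[N-])C(COC(=O)OCCCCCO)O2)c(=O)[nH]c1=O` gives > 50000 nM, which is also a limit of the assay.

Compound 2 sits at the limit of > 50000 nM in this assay, at which 2 of the 2 values shown sit, so no number is known for it. For the measured compounds named here, the only measured step, a step that the two limits leave unreadable from compound 1 to compound 2, gives no size to lean on. Compound 3 `Cc1cn(C2CC(N=[N+]=[N-])C(COC(=O)CCCN)O2)c(=O)[nH]c1=O` differs from compound 2 by 3-aminopropyl in place of (5-hydroxypentyl)oxy on a carbonyl carbon. With both values at the limit, no step beyond the scatter can be read, and none is expected in this assay. Compound 3 is therefore expected at 50000 nM, between 20000 nM and 150000 nM, most likely reported again only as a limit. The expected step is a number no higher from compound 2 to compound 3 (the limit leaves the size open).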

Compound 3, half-maximal cytotoxic concentration: > 50000 nM
Compound 3: a limit, no number; the forecaster's own chance of this, stated with the estimate: 75%; the middle value sits exactly at the limit.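

No step can be read among compound 1, compound 2 and compound 3, as all three remain limits and not numbers: the limit of > 50000 nM in this assay, at which 3 of the 3 values shown sit.

The compounds shown leave open the actual half-maximal cytotoxic concentration of each compound in this assay.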